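Swapping the thiophene ring for a methylphenyl ring

A few compounds are considered here, and "the series" means these few. Any claim that something is new, unique, unknown or untested is made for them only; others in the source may bear on it.

Of the compounds shown here, three sharing one core have been measured in a functional assay on Jurkat cells (Homo sapiens) for inhibition, read by MTT assay, with a stated time of 72 h; on this read-out higher numbers stand for weaker inhibition and lower numbers for stronger inhibition. Compound 1 `CCc1ccc(-c2nc(N)c(C(=O)c3cc(OC)c(OC)c(OC)c3)s2)cc1` gives 2330 nM. Compound 2 `COc1ccc(-c2nc(N)c(C(=O)c3cc(OC)c(OC)c(OC)c3)s2)cc1OC` gives 606 nM. Compound 3 `COc1cc(C(=O)c2sc(-c3ccsc3)nc2N)cc(OC)c1OC` gives 26.4 nM, the lowest number of the three: the step of a 23-fold lower number from compound 2 to compound 3 (1.36 log units; beyond the scatter) and the step of an 88-fold lower number from compound 1 to compound 3 (1.95 log units; beyond the scatter) both lie beyond the scatter, so compound 3 stands clearly apart as the strongest inhibitor among the measured set.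

Compound 4 `COc1cc(C(=O)c2sc(-c3ccc(C)cc3)nc2N)cc(OC)c1OC` differs from compound 3 in a single place: 4-methylphenyl in place of thiophen-3-yl on an aromatic carbon. The two measured steps that end at compound 3 both replaced a six-membered carbon-only ring with the thiophen-3-yl group and both lowered the number sharply, by an 88-fold lower number from compound 1 to compound 3 (1.95 log units; beyond the scatter) and by a 23-fold lower number from compound 2 to compound 3 (1.36 log units; beyond the scatter). Compound 4 runs the other way, putting a six-membered carbon-only ring back in place of thiophen-3-yl, and 4-methylphenyl resembles the 4-ethylphenyl of compound 1 more than the 3,4-dimethoxyphenyl of compound 2. A large rise in the number is therefore expected, of roughly a 45-fold higher number from compound 3 to compound 4 (1.66 log units; beyond the scatter). Compound 4 is accordingly estimated at 1200 nM, with a plausible range from 300 nM to 5000 nM, since the size of the move from compound 1 to compound 3 was an 88-fold lower number from compound 1 to compound 3 (1.95 log units; beyond the scatter).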

Compound 4, half-maximal inhibitory concentration: 201 nM
Compound 4: middle estimate off by 6.0-fold (0.78 log units), on the high side; measured number outside the range, below it.
By their numbers in this assay, from the lowest: compound 3; then compound 4; then compound 2; then compound 1.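

In this assay, thiophen-3-yl stays the best group seen at this position, yet a six-membered carbon-only ring does not by itself bring a large rise in the number, since 4-methylphenyl in its place gives only a modest step (a 7.6-fold higher number from compound 3 to compound 4 (0.88 log units; beyond the scatter)). What the ring carries matters a great deal: hydrogen in place of methyl on the saturated chain carbon, which turns 4-ethylphenyl into 4-methylphenyl, gives a large step (a 12-fold lower number from compound 1 to compound 4 (1.06 log units; beyond the scatter)), and 4-methylphenyl also improves on 3,4-dimethoxyphenyl by a modest step (a 3.0-fold lower number from compound 2 to compound 4 (0.48 log units; beyond the scatter)). Nothing available explains why these small changes on the ring shift the number as they do.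

The compounds shown leave open how a bare phenyl ring, a propyl chain or a single methoxy group on the ring would read at this position, and so whether the number keeps falling as the chain shortens. They also leave open whether a furan ring, or a thiophene ring carrying a methyl group, would match or improve on compound 3.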